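The source may hold more compounds than are shown below. What is called first, only, known or untested is meant among the compounds shown, and "the series" means these compounds.

The measured compounds are compound 1 `Cc1cc(Cl)cc(-c2ccnc3cc(CN4C(=O)C5CC5C4=O)sc23)c1O[C@@H]1CCNC[C@@H]1C`, compound 2 `Cc1cc(Cl)cc(-c2ccnc3cc(CN4C(=O)CCC4=O)sc23)c1O[C@@H]1CCNC[C@@H]1C` and compound 3 `Cc1cc2nccc(-c3cc(Cl)cc4c3O[C@@H](C(=O)N3CCNCC3)C4)c2s1`. In an assay on isolated protein for inhibition of ubiquitin carboxyl-terminal hydrolase 7 (Homo sapiens), read by fluorescence, with stated times of 30 min and 1 h (a higher number here means a weaker inhibitor, a lower number a stronger inhibitor), compound 1 gives 1.1 nM, compound 2 gives 2.1 nM and compound 3 gives 130 nM.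

Compound 2 stands second highest of the three numbers. Its nearest neighbour is compound 1, with a step of a 1.9-fold higher number from compound 1 to compound 2 (0.28 log units; within the scatter), while compound 3 lies far above it. Compound 4 `Cc1cc(Cl)cc(-c2ccnc3cc(CN4C(=O)CCC4=O)sc23)c1CN1CCNC[C@@H]1C` differs from compound 2 in one place: (2-methylpiperazin-1-yl)methyl in place of (3-methylpiperidin-4-yl)oxy on an aromatic carbon. Among the measured compounds shown here, the only step measured between compounds that differ in one place, from compound 1 to compound 2, concerns another part of the molecule and is within the scatter, so it says nothing about the present change. Compound 3 differs from compound 4 in several places, so its value is no guide either. For the measured compounds named here, with no measured step bearing on this exchange, the expectation rests on the size of the change alone: the expected step is a 5.7-fold higher number from compound 2 to compound 4 (0.76 log units; beyond the scatter), with a wide margin of uncertainty. Compound 4 is therefore estimated at 12 nM, within a range from 2 nM to 80 nM.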

Compound 4, half-maximal inhibitory concentration: 6.6 nM
Beside the measured number, compound 4's estimate is 1.8-fold (0.26 log units) above it; measured number inside the range.
By their numbers in this assay, from the lowest: compounds 1 and 2 (each within the scatter of the next); then compound 4; then compound 3.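

Placing (2-methylpiperazin-1-yl)methyl in place of (3-methylpiperidin-4-yl)oxy on this aromatic carbon gives a 3.1-fold higher number from compound 2 to compound 4 (0.50 log units; beyond the scatter) in this assay, the first measured step at this position, and it is modest in size. The position therefore accepts a different attachment and a different ring, with compound 4 still at 6.6 nM even though the two groups match in heavy atoms, hydrogen-bond donors and hydrogen-bond acceptors. Nothing measured here accounts for the step.

The link to the ring, the ring itself and the number of defined stereocentres all change at once, so the compounds shown do not separate their contributions. On these data alone, how an unsubstituted piperazine or a morpholine would behave on the same methylene link remains open.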